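Swapping a pyridin-4-yl ring for ethoxy

The compounds below may be only part of what the source reports. "The series", "measured", "known", "first", "only" and "open" are said of these compounds alone.

compound 1 `CC(C)(C)n1cc2c(n1)C(=O)CC1(CCN(C(=O)c3cc(-c4ccc(Br)cc4)nc4ccccc34)CC1)O2` gives 820 nM
compound 2 `CN(C)c1ccc(-c2cc(C(=O)N3CCC4(CC3)CC(=O)c3nn(C(C)(C)C)cc3O4)c3ccccc3n2)cc1` gives 1730 nM
compound 3 `CC(C)(C)n1cc2c(n1)C(=O)CC1(CCN(C(=O)c3cc(-c4ccncc4)nc4ccccc34)CC1)O2` gives 380 nM

In a functional assay on HepG2 cells (Homo sapiens) for inhibition, read by MTT assay, with a stated time of 72 h (on this read-out higher numbers stand for weaker inhibition and lower numbers for stronger inhibition), compound 3 stands lowest of the three (380 nM). Compound 4 `CCOc1cc(C(=O)N2CCC3(CC2)CC(=O)c2nn(C(C)(C)C)cc2O3)c2ccccc2n1` is not yet measured. It carries ethoxy in place of pyridin-4-yl on an aromatic carbon, next to the ring nitrogen (ethoxy in place of pyridin-4-yl on an aromatic carbon). The closest evidence is two swaps of one ring for another at this carbon (a 2.2-fold lower number from compound 1 to compound 3 (0.33 log units; beyond the scatter)) and (a 4.6-fold lower number from compound 2 to compound 3 (0.66 log units; beyond the scatter)). Both were modest, and in both pyridin-4-yl gave the lower number. Going by the values given here, no measured compound lacks a ring here, so the size of the step is uncertain. In this assay a modest step to a higher number is expected (a 2.4-fold higher number from compound 3 to compound 4 (0.37 log units; beyond the scatter)). Compound 4 is estimated at 900 nM with an expected range (300 nM to 2800 nM).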

Compound 4, half-maximal inhibitory concentration: > 10000 nM
Compound 4: no number, only a limit; the forecaster's own chance of this, stated with the estimate: 3%; middle value at least 11-fold (1.04 log units) away from the limit.
By their numbers in this assay, from the lowest: compound 3; then compound 1; then compound 2. At a limit, above all of these: compound 4.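

In this assay, compound 4 gives no number, only a limit: the limit of > 10000 nM in this assay, at which 1 of the 4 values shown sits.

Swapping one ring for another at this carbon had moved the number only modestly, but ethoxy, the only group here without a ring, gives an at least 26-fold higher number from compound 3 to compound 4 (1.42 log units; beyond the scatter). The same holds against the other two ring-bearing compounds, with an at least 12-fold higher number from compound 1 to compound 4 (1.08 log units; beyond the scatter) and an at least 5.7-fold higher number from compound 2 to compound 4 (0.76 log units; beyond the scatter).

Whether a ring at this carbon is needed remains open, as ethoxy is the only non-ring group shown. A simple amine such as dimethylamino directly on this carbon, or a longer chain such as butoxy, could help separate these possibilities.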